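One Methoxy Group Fewer: What Compound 4 Should Show

The source may hold more compounds than are shown below. What is called first, only, known or untested is meant among the compounds shown, and "the series" means these compounds.

Measured so far in a functional assay on NCI/ADR-RES cells (Homo sapiens) for inhibition, read by sulforhodamine B assay, with a stated time of 48 h; a higher number here means that more compound is tolerated, a lower number that less compound is tolerated:
Compound 1, `COc1ccc(-c2cc(/C=C/C(=O)c3ccc(N)cc3)[nH]n2)cc1`, gives > 100000 nM, which is a limit of the assay and not a number.
Compound 2, `COc1cc(-c2cc(/C=C/C(=O)c3ccc(N)cc3)[nH]n2)cc(OC)c1OC`, gives > 100000 nM, again a limit of the assay.
Compound 3, `COc1ccc(C(=O)/C=C/c2cc(-c3cc(OC)c(OC)c(OC)c3)n[nH]2)cc1OC`, gives > 100000 nM, also a limit of the assay.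

Compound 2 therefore stands not at a number but at a limit in this assay, and the two other values shown are limits as well. The only step among these compounds that joins two measured values, a step that the two limits leave unreadable from compound 2 to compound 3, cannot be read in size, since both of its ends are limits. Compound 4, `COc1ccc(-c2cc(/C=C/C(=O)c3ccc(N)cc3)[nH]n2)cc1OC`, differs from compound 2 by hydrogen in place of methoxy on an aromatic carbon. Among the compounds with values here, no measured step covers this change directly. What the measurements do show is the limit of > 100000 nM in this assay, at which 3 of the 3 values shown sit, so nothing points toward a value inside the readable range. For compound 4 the expected outcome is another limit, with a step that the limit leaves unreadable from compound 2 to compound 4 as the expected step, meaning no change beyond the scatter. The estimate for compound 4 is 150000 nM, within 50000 nM to 500000 nM.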

Compound 4, concentration lethal to 50% of the cells: > 100000 nM
Compound 4: no number, only a limit; the forecaster's own chance of this, stated with the estimate: 80%; the middle value is on the limit's open side.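

In this assay compound 4 gives > 100000 nM, a limit of the assay and not a number. Its steps to compound 1 and compound 2 cannot be read in size. The compounds shown leave open how far any of them lies beyond that limit.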